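Halogen swap at the 4-bromophenyl end of the series

The source may hold more compounds than are shown below. What is called first, only, known or untested is meant among the compounds shown, and "the series" means these compounds.

Compound 2 `C=C1C[C@]23C[C@@]1(O)CC[C@H]2c1ccc(O)c(C)c1[C@@H]3Cn1cc(-c2ccc(Br)cc2)nn1` carries hydrogen on the oxygen on an aromatic ring of the shared core together with a 4-bromophenyl. In a functional assay on SW480 cells (Homo sapiens) for cytotoxicity, read by MTT assay, with a stated time of 4 days (a higher number here means a weaker inhibitor, a lower number a stronger inhibitor), compound 2 gives only the limit > 20000 nM. Compound 1 `C=C1C[C@]23C[C@@]1(O)CC[C@H]2c1ccc(OS(=O)(=O)c2ccc(C)cc2)c(C)c1[C@@H]3Cn1cc(-c2ccc(Br)cc2)nn1`, its (4-methylphenyl)sulfonyl counterpart, likewise returns only the limit > 20000 nM in this assay. The step that the two limits leave unreadable from compound 1 to compound 2 is therefore unreadable, and all that the numbers show is the limit of > 20000 nM in this assay, at which 2 of the 2 values shown sit. Compound 3 `C=C1C[C@]23C[C@@]1(O)CC[C@H]2c1ccc(O)c(C)c1[C@@H]3Cn1cc(-c2ccc(F)cc2)nn1` differs from compound 2 by fluoro in place of bromo on an aromatic carbon. For the measured compounds named here, no measured step involves this halogen exchange, so no size or direction can be drawn from the numbers, and the only anchor is that compound 2 sits at a limit. The expectation is therefore that compound 3 also remains at that limit in this assay, with the step of a number no higher from compound 2 to compound 3 (the limit leaves the size open) expected to be none beyond the scatter. Compound 3 is estimated at 20000 nM, within 8000 nM to 50000 nM.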

Compound 3, half-maximal inhibitory concentration: > 20000 nM
Compound 3: no number, only a limit (the forecaster's own chance of this, stated with the estimate: 80%); the middle value sits exactly at the limit.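

In this assay compound 3 gives > 20000 nM, which is a limit and not a number. For the compounds shown here, compound 2 gives the limit > 20000 nM, so no step from compound 2 to compound 3 can be read. The compounds shown leave open whether any change to this series gives a measurable value in this assay.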